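The compounds below may be only part of what the source reports. "The series", "measured", "known", "first", "only" and "open" are said of these compounds alone.

Compound 1 `Cc1c(C(=O)c2ccc(CN(C)C)cc2)oc2cc(-c3ccccc3)cc(O)c12` was tested in a functional assay on WI-38 VA13 cells (Homo sapiens) for cytotoxicity (a higher number here means that more compound is needed for the effect, a lower number that less compound is needed), and gives > 4 ug/mL, which is a limit of the assay rather than a number. Compound 2 `Cc1c(C(=O)c2cnc3ccccc3c2)oc2cc(-c3ccccc3)cc(O)c12` likewise gives only a limit, > 4 ug/mL. For the measured compounds named here, compound 1 therefore stands at the limit of > 4 ug/mL in this assay, at which 2 of the 2 values shown sit, and no measured step between compounds is available. Compound 3 `Cc1c(C(=O)c2ccc(Oc3ccccc3)cc2)oc2cc(-c3ccccc3)cc(O)c12` differs from compound 1 by phenoxy in place of (dimethylamino)methyl on an aromatic carbon. Going by the values given here, with no measured step to lean on, the expected change in this assay is none beyond the scatter, so the step that the limit leaves unreadable from compound 1 to compound 3 is an estimate only. Compound 3 is expected to give about 6 ug/mL, between 3 ug/mL and 20 ug/mL, and most likely to be reported again as a limit.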

Compound 3, half-maximal effective concentration: > 4 ug/mL
Compound 3 gave a limit, no number; the forecaster's own chance of this, stated with the estimate: 80%; the middle value lies beyond the limit too.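

For the compounds shown here, compound 3, like compound 1, gives only a limit in this assay, so no step between the two can be read. The compounds shown leave open what concentration gives the effect for any of them.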